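Amino for chloro step in a benzylic chloride series

This account rests on a few compounds, and the source may have more. Where it says the series, first, only, none or still open, it means among the compounds named here.

Of the compounds shown here, three have been measured in a functional assay on IGROV-1 cells (Homo sapiens) for cytotoxicity, read by sulforhodamine B assay, with a stated time of 48 h; on this read-out lower numbers stand for stronger inhibition of growth and higher numbers for weaker inhibition of growth. Compound 3 `ClCc1ccc(Cn2cnc3c(Cl)nc(Cl)nc32)cc1` gives 15100 nM. Compound 1 `Nc1nc(Cl)c2ncn(Cc3ccc(CCl)cc3)c2n1` gives 9120 nM. Compound 2 `ClCc1cccc(Cn2cnc3c(Cl)nc(Cl)nc32)c1` gives 2290 nM; the difference between its core and the core of compound 3 is not broken down here, and the numbers show compound 2 with the lowest of the three, beyond the scatter from each of the other two.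

The change made from compound 3 to compound 1 is amino in place of chloro on an aromatic carbon and gave a step of a 1.7-fold lower number from compound 3 to compound 1 (0.22 log units; within the scatter). The same kind of change is now to be made from compound 2 to compound 4 `Nc1nc(Cl)c2ncn(Cc3cccc(CCl)c3)c2n1`, namely (amino in place of chloro on an aromatic carbon); the place of the change is the same word for word in both pairs, so this is one change seen twice in the series. The coming step is expected to be a 1.5-fold lower number from compound 2 to compound 4 (0.18 log units; within the scatter), set beside the earlier 1.7-fold lower number from compound 3 to compound 1 (0.22 log units; within the scatter), and rests only on that single measured pair and on the starting value of compound 2 in this assay. Compound 4 is therefore estimated at 1500 nM, expected to fall between 600 nM and 4000 nM.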

Compound 4, concentration for 50% growth inhibition: 3460 nM
Compound 4: the middle estimate sits 2.3-fold (0.36 log units) below what was measured; the measured number falls inside the stated range.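

In this assay, amino in place of chloro on an aromatic carbon gives a 1.5-fold higher number from compound 2 to compound 4 (0.18 log units; within the scatter), so on this second core the change again leaves the number within the scatter. Set beside the earlier step, the change carries over from one core to the other with no difference that can be read: the same change on two cores in this assay, a 1.7-fold lower number (0.22 log units; within the scatter) from compound 3 to compound 1 and a 1.5-fold higher number (0.18 log units; within the scatter) from compound 2 to compound 4, 2.5-fold (0.40 log units) apart, within the scatter of two such steps. Among these compounds, the two steps point opposite ways on paper, but neither is beyond the scatter, so the pairs show no effect of the change on either core, give it no direction, and with only two cores say nothing about how it would behave on a third.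

The compounds shown leave open whether a methylamino or a methoxy group at the same place would also stay within the scatter. They also leave open whether the step would hold on a core where a hydroxymethyl group stands in place of the chloromethyl group.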